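From Thiophen-3-yl to 4-Ethoxyphenyl on the Shared Core

The source may hold more compounds than are shown below. What is called first, only, known or untested is meant among the compounds shown, and "the series" means these compounds.

In a functional assay on CCRF-CEM cells (Homo sapiens) for antiproliferative activity (on this read-out lower numbers stand for stronger inhibition and higher numbers for weaker inhibition), compound 2 (`COc1cc(C(=O)c2sc(-c3ccccc3)cc2N)cc(OC)c1OC`) gives 4.5 nM. Within the data shown here, compound 3 (`COc1cc(C(=O)c2sc(-c3ccsc3)cc2N)cc(OC)c1OC`) gives 9.6 nM, the higher of the two numbers measured so far. The gap between them is a 2.1-fold higher number from compound 2 to compound 3 (0.33 log units; beyond the scatter), a modest step. Compound 1 (`COc1cc(C(=O)c2sc(-c3ccc(-c4ccccc4)cc3)cc2N)cc(OC)c1OC`) reports only a limit of the assay, > 10000 nM.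

Compound 4 (`CCOc1ccc(-c2cc(N)c(C(=O)c3cc(OC)c(OC)c(OC)c3)s2)cc1`) has not yet been measured. It differs from compound 3 at a single place: 4-ethoxyphenyl in place of thiophen-3-yl on an aromatic carbon. In short, 4-ethoxyphenyl stands in place of thiophen-3-yl on an aromatic carbon, next to the ring sulfur.

Among the measured compounds shown here, two measured steps bear on this change. The swap between phenyl and thiophen-3-yl at this place gave a 2.1-fold higher number from compound 2 to compound 3 (0.33 log units; beyond the scatter), so compound 3 sits close to compound 2. The other step is large: an at least 2200-fold lower number from compound 1 to compound 2 (3.34 log units; beyond the scatter), with hydrogen in place of phenyl on an aromatic carbon of the group at this place. For the measured compounds named here, compound 1 is a warning that adding to that group can cost nearly all activity, but it is a single case, and no measured compound carries an ethoxy group.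

A modest step is therefore expected, towards a higher number, and the upper end of the range is kept wide. The expected step is a 2.1-fold higher number from compound 3 to compound 4 (0.32 log units; beyond the scatter). Compound 4 is estimated at 20 nM, with an expected range from 3 nM to 300 nM.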

Compound 4, half-maximal inhibitory concentration: 270 nM
For compound 4 the middle estimate is 14-fold (1.13 log units) below the measured one; measured number inside the range.
By their numbers in this assay, from the lowest: compound 2; then compound 3; then compound 4. At a limit, above all of these: compound 1.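

In this assay, ethoxy on the phenyl group gives a 60-fold higher number from compound 2 to compound 4 (1.78 log units; beyond the scatter), and the exchange of thiophen-3-yl for 4-ethoxyphenyl gives a 28-fold higher number from compound 3 to compound 4 (1.45 log units; beyond the scatter), so the group on this aromatic carbon next to the ring sulfur does not take a modest addition freely. Compound 1 is no longer a single case: both compounds shown with an addition on that phenyl group, compound 1 and compound 4, stand higher than compound 2, and none goes against this, yet ethoxy keeps measurable inhibition, with an at least 37-fold lower number from compound 1 to compound 4 (1.56 log units; beyond the scatter). That last step is bounded on one side only, since the value of compound 1 is a limit and not a number: the limit of > 10000 nM in this assay, at which 1 of the 4 values shown sits.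

The compounds shown leave open whether the loss belongs to ethoxy itself or to any addition on the phenyl group, since a methoxy group, a fluorine atom or a hydroxyl group there has no value here. They also leave open how an amine or a carboxylic acid on that group would compare with ethoxy.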